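The compounds below may be only part of what the source reports. "The series", "measured", "known", "first", "only" and "open" are said of these compounds alone.

Compound 1 `CC1CCC(C[C@H](NC(=O)c2ccco2)C(=O)N[C@H]2CC[C@@H](C)N(S(=O)(=O)c3ccccn3)CC2=O)CC1` carries a 4-methylcyclohexyl group on a saturated chain carbon of its shared core. Within the data shown here, in an assay on isolated protein for inhibition of cathepsin S (Homo sapiens), read by fluorescence (on this read-out higher numbers stand for weaker inhibition and lower numbers for stronger inhibition), compound 1 gives 0.5 nM, the lowest of the two numbers measured so far. Compound 2 `C[C@@H]1CC[C@H](NC(=O)[C@H](CCC2CCCC2)NC(=O)c2ccco2)C(=O)CN1S(=O)(=O)c1ccccn1` differs from compound 1 in one place only, cyclopentylmethyl in place of 4-methylcyclohexyl, and in this assay compound 2 gives 1.9 nM. That change reads as a 3.8-fold higher number from compound 1 to compound 2 (0.58 log units; beyond the scatter). Compound 3 `C[C@@H]1CC[C@H](NC(=O)[C@H](CC2CCC(C)(C)CC2)NC(=O)c2ccco2)C(=O)CN1S(=O)(=O)c1ccccn1` has not yet been measured; it differs from compound 1 by methyl in place of hydrogen on a saturated ring carbon. Among the measured compounds shown here, the only measured step that touches this part of the molecule is the one from compound 1 to compound 2, which swapped the whole ring for a different one and cost a modest amount; the step to compound 3 is gentler, adding a methyl while keeping the ring itself. Since compound 1 already sits at the strong end, a small drift toward higher numbers is the more likely outcome. The expected step is therefore a 1.6-fold higher number from compound 1 to compound 3 (0.20 log units; within the scatter), at the edge of the scatter. Compound 3 is estimated to give 0.8 nM in this assay, with a likely range from 0.3 nM to 2.5 nM.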

Compound 3, half-maximal inhibitory concentration: 1.2 nM
Compound 3: middle estimate off by 1.5-fold (0.18 log units), on the low side, and the stated range covers the measured number.
By their numbers in this assay, from the lowest: compound 1; then compounds 3 and 2 (each within the scatter of the next).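

In this assay, a single methyl added on a saturated ring carbon, three ring bonds from the ring atom that bears a large group, gives a 2.4-fold higher number from compound 1 to compound 3 (0.38 log units; beyond the scatter). This position therefore responds to one extra carbon, even though the ring itself stays in place and 4-methylcyclohexyl simply becomes 4,4-dimethylcyclohexyl. The other new step, a 1.6-fold lower number from compound 2 to compound 3 (0.20 log units; within the scatter), stays inside the scatter, so the two edits to the group on the chain, the cyclopentylmethyl and the 4,4-dimethylcyclohexyl, cannot be told apart on this read-out, and nothing measured here accounts for either step.

The compounds shown leave open how the number would respond at this ring carbon to a group other than methyl, such as an ethyl, a hydroxyl or an amine. They also leave open where a plain cyclohexyl ring, carrying no methyl at all, would fall, and so whether the first methyl on this ring carbon moves the number in the same direction as the second.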